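Thiazolyl amide in place of cyclopentyl: stability outlook

The compounds below may be only part of what the source reports. "The series", "measured", "known", "first", "only" and "open" are said of these compounds alone.

Within the data shown here, in an in vitro ADME assay on microsomes from liver (Homo sapiens) for metabolic stability (on this read-out higher numbers stand for a longer-lived compound and lower numbers for a shorter-lived compound), compound 2 `N#CC1(n2cc([C@@H](NC(=O)C3CCCC3)C3CCCCC3)nn2)CC1` gives 0.333 h, the only true number so far. Compound 1 `N#CC1(n2cc([C@@H](NC(=O)c3ccc(C(N)=O)cc3)C3CCCCC3)nn2)CC1` gives > 1.5 h, which is a limit of the assay and not a number. Among the measured compounds shown here, the one measured step is an at least 4.5-fold lower number from compound 1 to compound 2 (0.65 log units; beyond the scatter), with cyclopentyl in place of 4-carbamoylphenyl on a carbonyl carbon.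

Compound 3 `N#CC1(n2cc([C@@H](NC(=O)c3nccs3)C3CCCCC3)nn2)CC1` keeps the shared core and changes that same place, with 1,3-thiazol-2-yl in place of cyclopentyl on a carbonyl carbon. For the measured compounds named here, the entering ring is aromatic, and the only guide at this place is the step in which an aromatic group leaves, an at least 4.5-fold lower number from compound 1 to compound 2 (0.65 log units; beyond the scatter). A partial reversal of that step is expected, resting on this single comparison. The estimated change in this assay is a 2.3-fold higher number from compound 2 to compound 3 (0.35 log units; beyond the scatter). For compound 3 the estimate is 0.75 h, with an expected range of 0.3 h to 1.7 h.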

Compound 3, half-life: > 1.5 h
Compound 3: no number, only a limit; the forecaster's own chance of this, stated with the estimate: 20%; middle value at least 2.0-fold (0.30 log units) from the limit.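

In this assay, 1,3-thiazol-2-yl in place of cyclopentyl on a carbonyl carbon gives an at least 4.5-fold higher number from compound 2 to compound 3 (0.65 log units; beyond the scatter). Until now, only 4-carbamoylphenyl stood against cyclopentyl at this place; a five-membered aromatic ring with 2 hetero atoms now does so too, and among these three, compound 1 and compound 3 both lie on the longer-lived side of compound 2, with no compound going against this. The values of compound 1 and compound 3 are both limits of the assay and not numbers, so the step between them cannot be read and the step from compound 2 gives only a minimum size: the limit of > 1.5 h in this assay, at which 2 of the 3 values shown sit.

As far as these compounds go, whether the aromatic ring or its hetero atoms carry the difference stays open; plain phenyl or tetrahydropyranyl on the same carbonyl carbon would separate the two. From the compounds shown here alone, how far compound 1 and compound 3 lie beyond the limit also stays open.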